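Ortho substituent swap on the phenoxy ring

The source may report more compounds than this note shows. Statements on the series, on what has been measured and on what is new or still open speak of the compounds shown alone.

Measured compounds:
compound 1, `CCNC(=O)c1cccc(Cn2nc(C)c(NC(=O)c3ccc(COc4ccccc4)cc3)c2C)c1`, in a functional assay on MIA PaCa-2 cells (Homo sapiens) for antiproliferative activity, read by MTT assay, with a stated time of 72 h (a higher number here means that more compound is needed for the effect, a lower number that less compound is needed), compound 1 gives 11000 nM
compound 2, `Cc1nn(Cc2cccc(C(=O)NC(C)C)c2)c(C)c1NC(=O)c1ccc(COc2ccccc2)cc1`, in this assay compound 2 gives 8900 nM
compound 3, `CNC(=O)c1cccc(Cn2nc(C)c(NC(=O)c3ccc(COc4ccccc4C)cc3)c2C)c1`, in this assay compound 3 gives 2100 nM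

Compound 3 has the lowest number of the three in this assay, and its gaps to compound 2 and to compound 1 are both beyond the scatter. Compound 4, `CNC(=O)c1cccc(Cn2nc(C)c(NC(=O)c3ccc(COc4ccccc4OC)cc3)c2C)c1`, differs from compound 3 by methoxy in place of methyl on an aromatic carbon.

Going by the values given here, the only measured step, a 1.2-fold lower number from compound 1 to compound 2 (0.09 log units; within the scatter), concerns the amide substituent on the other end of the core and is within the scatter, so it offers no guide to a change on the phenoxy ring. Among the compounds with values here, no measured pair here varies the group on that ring. With nothing to point either way, compound 4 is expected to stay close to compound 3, and the expected step of a 1.2-fold higher number from compound 3 to compound 4 (0.08 log units; within the scatter) is within the scatter. For compound 4 the estimate in this assay is 2500 nM, with a range from 900 nM to 7000 nM.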

Compound 4, half-maximal effective concentration: 8500 nM
For compound 4 the middle estimate is 3.4-fold (0.53 log units) below the measured one, outside the stated range (above it).
By their numbers in this assay, from the lowest: compound 3; then compounds 4, 2 and 1 (each within the scatter of the next).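

In this assay, going by these compounds alone, going from 2-methylphenoxy to 2-methoxyphenoxy gives a 4.0-fold higher number from compound 3 to compound 4 (0.61 log units; beyond the scatter), the first sign that the group at this place on the ring affects the result, which no earlier pair could show. The swap adds only one heavy atom, an oxygen that counts as a hydrogen-bond acceptor, yet the step lies beyond the scatter. Nothing available explains why the two groups differ.

Compounds 1 and 2 carry an unsubstituted phenoxy ring but a different amide substituent, so they give no clean reference for how either group compares with hydrogen. Also open, from the compounds shown here alone, is how a chlorine atom, an ethyl group or a hydroxyl group at this place would compare with methyl and methoxy, and whether the step holds with the larger amide substituents.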